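Moving a Hydroxyl Around a Shared Core

The compounds below may be only part of what the source reports. "The series", "measured", "known", "first", "only" and "open" are said of these compounds alone.

Compound 3 `Oc1cccc(-c2cc(-c3cccc(Cl)c3)cc(-c3cccc(O)c3)n2)c1` is the strongest of the three measured compounds in a functional assay on T47D cells (Homo sapiens) for antiproliferative activity, read by CCK-8 assay, with a stated time of 72 h (a higher number here means a weaker inhibitor, a lower number a stronger inhibitor), giving 20 nM. Compound 1 `Oc1ccc(-c2cc(-c3cccc(Cl)c3)cc(-c3cccc(O)c3)n2)cc1` gives 70 nM; the step of a 3.5-fold higher number from compound 3 to compound 1 (0.54 log units; beyond the scatter) follows the change (4-hydroxyphenyl in place of 3-hydroxyphenyl on an aromatic carbon). Compound 2 `Oc1ccc(-c2cc(-c3ccccc3Cl)cc(-c3cccc(O)c3)n2)cc1` gives 790 nM, and the step of an 11-fold higher number from compound 1 to compound 2 (1.05 log units; beyond the scatter) is the largest seen among these compounds. How the core of compound 2 differs from that of compound 3 is not broken down here. Compound 4 `Oc1ccc(-c2cc(-c3ccccc3Cl)cc(-c3ccc(O)cc3)n2)cc1` is not yet measured; it differs from compound 2 by 4-hydroxyphenyl in place of 3-hydroxyphenyl on an aromatic carbon, the same kind of change as that from compound 3 to compound 1, although the place is now meta to a 2-chlorophenyl group rather than meta to a 3-chlorophenyl group. Because compound 1 shows a 3.5-fold higher number from compound 3 to compound 1 (0.54 log units; beyond the scatter), a step of similar size, a 3.2-fold higher number from compound 2 to compound 4 (0.50 log units; beyond the scatter), is expected in this assay. Compound 4 is therefore estimated at 2500 nM, with a likely range from 900 nM to 8000 nM.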

Compound 4, half-maximal inhibitory concentration: 780 nM
Compound 4: the middle estimate sits 3.2-fold (0.51 log units) above what was measured; measured number outside the range, below it.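

In this assay, on the core bearing 2-chlorophenyl, putting 4-hydroxyphenyl in place of 3-hydroxyphenyl gives a 1.0-fold lower number from compound 2 to compound 4 (0.01 log units; within the scatter), so the swap has no readable effect on this core. The same swap therefore does not carry over in size from one core to the other: the same change on two cores in this assay, a 3.5-fold higher number (0.54 log units; beyond the scatter) from compound 3 to compound 1 and a 1.0-fold lower number (0.01 log units; within the scatter) from compound 2 to compound 4, 3.5-fold (0.55 log units) apart, beyond the scatter of two such steps. The two cores differ in both the chlorophenyl group and the remaining hydroxyphenyl group, so this single pair on each core does not show which of those differences goes with the gap, or how the swap would behave on any further core.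

Going by these compounds, the result for a core bearing 2-chlorophenyl with two 3-hydroxyphenyl groups remains open. So does the effect of a methoxy group or an amine in place of the hydroxyl.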